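Amide-end variation on the nitrobenzofurazan thioether series

The source may hold more compounds than are shown below. What is called first, only, known or untested is meant among the compounds shown, and "the series" means these compounds.

Measured so far:
compound 1 `O=C(CCC(=O)OCCCCCCSc1ccc([N+](=O)[O-])c2nonc12)Nc1ccccc1` — 10200 nM
compound 2 `Cc1ccccc1NC(=O)CCC(=O)OCCCCCCSc1ccc([N+](=O)[O-])c2nonc12` — 4100 nM
compound 3 `CCN(CC)CCCNC(=O)CCC(=O)OCCCCCCSc1ccc([N+](=O)[O-])c2nonc12` — 9550 nM

All three share the core of compound 1 and differ only in the group on the amide-type nitrogen. In an assay on isolated protein for inhibition of glutathione S-transferase P (Homo sapiens), with a stated time of 10 min (a lower number here means a stronger inhibitor, a higher number a weaker inhibitor), compound 3 gives 9550 nM, the second highest of the three numbers. Its nearest neighbour is compound 1: the step of a 1.1-fold lower number from compound 1 to compound 3 (0.03 log units; within the scatter) lies within the scatter. The step of a 2.3-fold higher number from compound 2 to compound 3 (0.37 log units; beyond the scatter) is modest, and a 2.5-fold lower number from compound 1 to compound 2 (0.40 log units; beyond the scatter) is modest as well, so changes at this end of the molecule have so far moved this assay by small amounts only.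

Compound 4 `O=C(CCC(=O)N1CCOCC1)OCCCCCCSc1ccc([N+](=O)[O-])c2nonc12` carries the change (morpholin-4-yl in place of (3-(diethylamino)propyl)amino on a carbonyl carbon). Among the measured compounds shown here, the steps that bear on it are those at the same amide end, a 1.1-fold lower number from compound 1 to compound 3 (0.03 log units; within the scatter) and a 2.3-fold higher number from compound 2 to compound 3 (0.37 log units; beyond the scatter), neither of which exceeds a modest size. The expectation for compound 4 is therefore a step of a 1.0-fold higher number from compound 3 to compound 4 (0.02 log units; within the scatter) in this assay, that is, no change beyond the scatter, with a slight drift towards a higher number held possible. Compound 4 is estimated at 10000 nM, with a range from 4500 nM to 22000 nM.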

Compound 4, half-maximal inhibitory concentration: 330 nM
Compound 4: the middle estimate sits 30-fold (1.48 log units) above what was measured; measured number outside the range, below it.
By their numbers in this assay, from the lowest: compound 4; then compound 2; then compounds 3 and 1 (each within the scatter of the next).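

Read in this assay, the amide end is far more sensitive than compounds 1 to 3 suggested: a 29-fold lower number from compound 3 to compound 4 (1.46 log units; beyond the scatter) is a large step, as are a 12-fold lower number from compound 2 to compound 4 (1.09 log units; beyond the scatter) and a 31-fold lower number from compound 1 to compound 4 (1.49 log units; beyond the scatter) when set against the other two groups. Anilino, (2-methylphenyl)amino and (3-(diethylamino)propyl)amino, though unlike one another, had been separated by modest steps at most, so the earlier spread gave no sign of a change of this size on the carbonyl carbon. In the computed comparison with compound 3, morpholin-4-yl brings one six-membered non-aromatic ring with 2 hetero atoms and 0 hydrogen-bond donors in place of an open chain with 1 hydrogen-bond donor, and these differences arrive together in a single change, so the gain cannot be assigned to any one of them.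

Piperidin-1-yl or diethylamino on the same carbonyl carbon would help separate the ring, its oxygen and the loss of the amide hydrogen, and the shown compounds cannot make that separation. No measurement at hand bears on the cause of this step.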